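The compounds below may be only part of what the source reports. "The series", "measured", "known", "first", "only" and "open" are said of these compounds alone.

Measured so far in a functional assay on A549 cells (Homo sapiens) for inhibition, read by MTT assay, with a stated time of 72 h; a lower number here means a stronger inhibitor, a higher number a weaker inhibitor:

- compound 1 `O=C(O)CCC(=O)OCCCCCCSc1ccc([N+](=O)[O-])c2nonc12`: compound 1 gives 3640 nM
- compound 2 `Cc1ccccc1NC(=O)CCC(=O)OCCCCCCSc1ccc([N+](=O)[O-])c2nonc12`: compound 2 gives 4200 nM
- compound 3 `O=C(CCC(=O)OCCCCCCSc1ccc([N+](=O)[O-])c2nonc12)Nc1ccc(F)cc1`: compound 3 gives 6300 nM

All three share the same core and differ only at the far end of the chain. Compound 2 holds the second highest of the three numbers in this assay; its nearest neighbour is compound 1, with a 1.2-fold higher number from compound 1 to compound 2 (0.06 log units; within the scatter), and its furthest is compound 3, with a 1.5-fold higher number from compound 2 to compound 3 (0.18 log units; within the scatter). Both steps sit inside the scatter, as does a 1.7-fold higher number from compound 1 to compound 3 (0.24 log units; within the scatter), so no ordering among the three can be claimed.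

Compound 4 `O=C(CCC(=O)OCCCCCCSc1ccc([N+](=O)[O-])c2nonc12)NCCN1CCCC1` is not yet measured. Relative to compound 2 the change is 2-(pyrrolidin-1-yl)ethyl in place of 2-methylphenyl on an amide-type nitrogen. Among the measured compounds shown here, no measured step exchanges an aromatic group for an amine-bearing chain at this position; the three steps seen so far only show that swapping a free acid for either of two anilides, or one anilide for the other, moves the number by less than the scatter. On that basis the step for compound 4 is expected to be a 1.1-fold higher number from compound 2 to compound 4 (0.03 log units; within the scatter), that is, none beyond the scatter. Compound 4 is therefore estimated at 4500 nM in this assay, with a range of 1800 nM to 11000 nM.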

Compound 4, half-maximal inhibitory concentration: 3240 nM
Compound 4: middle estimate off by 1.4-fold (0.14 log units), on the high side; low and high end bracket the measured number.
By their numbers in this assay, from the lowest: compounds 4, 1, 2 and 3 (each within the scatter of the next).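

In this assay an amine-bearing chain now stands on this amide-type nitrogen: 2-(pyrrolidin-1-yl)ethyl in place of the aromatic groups gives a 1.3-fold lower number from compound 2 to compound 4 (0.11 log units; within the scatter) and a 1.9-fold lower number from compound 3 to compound 4 (0.29 log units; within the scatter). Measured against the free acid, (2-(pyrrolidin-1-yl)ethyl)amino in place of hydroxy gives a 1.1-fold lower number from compound 1 to compound 4 (0.05 log units; within the scatter). All three steps lie within the scatter, so the exchange of a six-membered aromatic ring of carbon only for a five-membered non-aromatic ring with a hetero atom, which also brings in a hydrogen-bond acceptor, produces no readable step, and the set without a readable step at this end of the chain now covers the free acid, both anilides and this amine chain; nothing available bears on the reason for this.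

Open, going by these compounds, is whether a primary amine, a second carboxylic acid or a longer chain at this position would give a step beyond the scatter. Also open, on these data alone, is whether exchanges at this end of the chain stay within the scatter when the shared core or the chain leading to it is altered.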